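The compounds below may be only part of what the source reports. "The series", "measured", "known", "first", "only" and "open" are said of these compounds alone.

Compounds measured in a functional assay on ACHN cells (Homo sapiens) for antiproliferative activity, read by sulforhodamine B assay; on this read-out lower numbers stand for stronger inhibition of growth and higher numbers for weaker inhibition of growth:
Compound 1 `CCCCCCOc1cccc(O)c1C(=O)/C=C/c1ccc(O)cc1` gives > 30000 nM, a limit of this assay rather than a number.
Compound 2 `O=C(/C=C/c1ccc(O)cc1)c1c(O)cccc1OCCC1CCCC1` gives 3400 nM.
Compound 3 `O=C(/C=C/c1ccc(O)cc1)c1c(O)cccc1OCCC1CCCCC1` gives > 30000 nM, again a limit of this assay rather than a number.

Compound 3 thus stands at the limit (the limit of > 30000 nM in this assay, at which 2 of the 3 values shown sit), where two of the three values sit, and is not separated from compound 1 by a readable step: a step that the two limits leave unreadable from compound 1 to compound 3. Against compound 2 the picture is sharper, with an at least 8.8-fold higher number from compound 2 to compound 3 (0.94 log units; beyond the scatter), and compound 2 also sits well below compound 1, an at least 8.8-fold lower number from compound 1 to compound 2 (0.94 log units; beyond the scatter).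

Compound 4 `CCC(CC)COc1cccc(O)c1C(=O)/C=C/c1ccc(O)cc1` carries the change (pentan-3-yl in place of cyclohexylmethyl on a saturated chain carbon bound to an oxygen on an aromatic ring). Within the data shown here, the steps that bear on this are the two that run from the limit to compound 2 and back, both at least modest, and the unreadable step between compound 1 and compound 3. Compound 1, with an unbranched chain on that oxygen, sits at the limit, and compound 4 brings back an acyclic chain there, branched but of similar reach. The step of an at least 1.2-fold lower number from compound 3 to compound 4 (0.07 log units; that floor lies within the scatter) is therefore expected to be small or not readable beyond the scatter, with the greater chance that compound 4 also ends at a limit. Compound 4 is estimated at 25000 nM, with a range from 5000 nM to 100000 nM.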

Compound 4, concentration for 50% growth inhibition: 3370 nM
For compound 4 the middle estimate is 7.4-fold (0.87 log units) above the measured one, and the stated range ends above it.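

The pentan-3-yl group shows that a ring is not needed at this place for a readable value in this assay: in place of cyclohexylmethyl it gives an at least 8.9-fold lower number from compound 3 to compound 4 (0.94 log units; beyond the scatter), and in place of pentyl it gives an at least 8.9-fold lower number from compound 1 to compound 4 (0.94 log units; beyond the scatter). In place of cyclopentylmethyl it gives a 1.0-fold lower number from compound 2 to compound 4 (0.00 log units; within the scatter), so the open branched group and the ring-bearing group of compound 2 cannot be told apart here, and ring against chain does not by itself sort these compounds, given that compound 1 without a ring and compound 3 with one both stand at a limit of the assay. The two larger steps are therefore floors whose full size cannot be read, because both start from that limit: the limit of > 30000 nM in this assay, at which 2 of the 4 values shown sit.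

From the compounds shown here alone, whether a readable value survives with a shorter branched chain such as isobutyl, or with a smaller ring such as cyclobutylmethyl, remains open. So does whether an amine or a carboxylic acid at the end of the chain on this oxygen would keep the growth inhibition seen with compound 2 and compound 4.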